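Ring swap on the chain carbon in an EP3 antagonist series

This account rests on a few compounds, and the source may have more. Where it says the series, first, only, none or still open, it means among the compounds named here.

Measured so far:
compound 1 `C/C(=C1/OC(=O)NC1=O)C(c1ccc(-c2ccc3cccc(F)c3c2)[nH]c1=O)C(C)C` with 39 nM
compound 2 `CC(C)C(CC1C(=O)NC(=O)N1C)c1ccc(-c2ccc3cccc(F)c3c2)[nH]c1=O` with 65 nM

In a functional assay on CHO cells for antagonist activity at prostaglandin E2 receptor EP3 subtype (Homo sapiens), read by cAMP accumulation, with a stated time of 30 min (on this read-out lower numbers stand for stronger inhibition and higher numbers for weaker inhibition), compound 2 holds the highest of the two numbers; its nearest neighbour is compound 1, and the step of a 1.7-fold higher number from compound 1 to compound 2 (0.22 log units; within the scatter) lies within the scatter. Compound 3 `CC(C)C(/C=C1\SC(=O)NC1=O)c1ccc(-c2ccc3cccc(F)c3c2)[nH]c1=O` is drawn from compound 2 by a group of 8 heavy atoms (4 carbon, 1 nitrogen, 2 oxygen, 1 sulfur; one five-membered non-aromatic ring with 2 hetero atoms) in place of a group of 9 heavy atoms (5 carbon, 2 nitrogen, 2 oxygen; one five-membered non-aromatic ring with 2 hetero atoms), on a saturated chain carbon bound to an aromatic carbon and a saturated chain carbon. Going by the values given here, the only measured step that bears on this place is a 1.7-fold higher number from compound 1 to compound 2 (0.22 log units; within the scatter), where one five-membered non-aromatic ring with 2 hetero atoms was exchanged for another at the same saturated chain carbon without a change beyond the scatter. Compound 3 repeats such an exchange and restores a double bond outside aromatic rings, as in compound 1, so no step beyond the scatter is expected in this assay; if anything, the number is expected to sit near that of compound 1. Compound 3 is therefore estimated at 45 nM (range 15 nM to 140 nM), an expected step of a 1.4-fold lower number from compound 2 to compound 3 (0.16 log units; within the scatter).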

Compound 3, half-maximal inhibitory concentration in the prostaglandin E2 receptor EP3 subtype assay: 27 nM
Compound 3: the middle estimate sits 1.7-fold (0.22 log units) above what was measured; measured number inside the range.
By their numbers in the prostaglandin E2 receptor EP3 subtype assay, from the lowest: compounds 3, 1 and 2 (each within the scatter of the next, the first and the last beyond it).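

Going by these compounds alone, in the prostaglandin E2 receptor EP3 subtype assay the group holding sulfur, entering in place of the (3-methyl-2,5-dioxoimidazolidin-4-yl)methyl group, gives a 2.4-fold lower number from compound 2 to compound 3 (0.38 log units; beyond the scatter), the first modest step beyond the scatter at this saturated chain carbon, while a 1.4-fold lower number from compound 1 to compound 3 (0.16 log units; within the scatter) keeps the unsaturated compounds together. In a physicochemical assay for solubility, in phosphate buffer, measured as kinetic solubility (a lower number here means a less soluble compound, a higher number a more soluble compound), compound 2 gives 33600 nM and compound 3 gives 25600 nM, and a 1.3-fold lower number from compound 2 to compound 3 (0.12 log units; within the scatter) places the two within the scatter of each other. No evidence at hand accounts for the step.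

The step to compound 3 changes the ring atoms and the count of double bonds outside aromatic rings together, so the share of each stays unresolved. Also open, on these data alone, is how a carboxylic acid or an amine would read at this saturated chain carbon.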